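The compounds below may be only part of what the source reports. "The series", "measured", "known", "first", "only" and "open" are said of these compounds alone.

Three compounds have been measured in a functional assay on MDA-MB-231 cells (Homo sapiens) for inhibition, read by MTT assay, with a stated time of 72 h; a lower number here means a stronger inhibitor, a higher number a weaker inhibitor:

compound 1 `O=C(CSc1nc(Nc2ccccc2)c2ccccc2n1)Nc1ccc(F)cc1` gives 34100 nM
compound 2 `O=C(CSc1nc(Nc2ccccc2)c2ccccc2n1)Nc1ccc(Cl)cc1` gives 17200 nM
compound 3 `C=CC(=O)Nc1cccc(NC(=O)CSc2nc(Nc3cccc(F)c3)c3ccccc3n2)c1` gives 8160 nM

Compound 1 and compound 2 share one core and differ only in one spot: chloro in place of fluoro on an aromatic carbon. That exchange gave a 2.0-fold lower number from compound 1 to compound 2 (0.30 log units; within the scatter), a step the assay itself cannot tell apart from repetition. Compound 3 carries a different core, one that adds a further amide-bearing ring; how its core differs from that of compound 1 is not broken down here. Its number in this assay sits beyond the scatter from both compound 1 and compound 2.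

Compound 4 `C=CC(=O)Nc1cccc(NC(=O)CSc2nc(Nc3cccc(Cl)c3)c3ccccc3n2)c1` has not yet been measured. It differs from compound 3 by chloro in place of fluoro on an aromatic carbon. Within the data shown here, this is the same kind of change as the one from compound 1 to compound 2, though not the same: there the halogen sat para to a large group, here it sits meta to a large group, and the core around it is another one. Among the measured compounds shown here, only one earlier example of this exchange exists, and it moved the number by less than the usual scatter, so the expectation for compound 4 rests on a single, small step and on the value of compound 3. The expected step from compound 3 to compound 4 is a 1.8-fold lower number from compound 3 to compound 4 (0.26 log units; within the scatter), a little lower, mirroring the earlier one. Compound 4 is therefore estimated at 4500 nM in this assay, with a plausible range from 1800 nM to 12000 nM.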

Compound 4, half-maximal inhibitory concentration: 16300 nM
The estimate for compound 4 lay 3.6-fold (0.56 log units) below the measured number; measured number above the stated range.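

Swapping fluoro for chloro on the compound 3 core gives, in this assay, a 2.0-fold higher number from compound 3 to compound 4 (0.30 log units; within the scatter), so on its own this step cannot be told apart from repeating the measurement. Set beside the earlier example, however, the exchange does not behave as one fixed shift that can be carried from one core to the other: the same change on two cores in this assay, a 2.0-fold lower number (0.30 log units; within the scatter) from compound 1 to compound 2 and a 2.0-fold higher number (0.30 log units; within the scatter) from compound 3 to compound 4, 4.0-fold (0.60 log units) apart, beyond the scatter of two such steps This shows only that the result of the exchange on one core is a poor guide to its result on the other; it does not show that chloro is better or worse than fluoro on either core, since neither step alone stands clear of the scatter, and it gives no reason for the gap, since the two pairs differ both in their core and in where the halogen sits on the ring.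

The compounds shown leave open whether the gap comes from the core or from the halogen's place, which a fluoro and chloro pair with the halogen at the same place on both cores could separate. They also leave open how a methyl, a methoxy or a nitrile would compare with these halogens at the same place on the ring.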